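From Methyl to 4-Bromophenyl on the Aromatic Nitrogen

The source may report more compounds than this note shows. Statements on the series, on what has been measured and on what is new or still open speak of the compounds shown alone.

Measured compounds:
compound 1, `COc1cc(-c2nccn2C)cc(OC)c1OC`, > 100000 nM
compound 2, `COc1cc(-c2nccn2-c2ccc(C)cc2)cc(OC)c1OC`, 700 nM
compound 3, `COc1cc(-c2nccn2-c2ccc(Br)cc2)cc(OC)c1OC`, not yet measured

Of the compounds shown here, two sharing one core have been tested in a functional assay on HeLa cells (Homo sapiens) for antiproliferative activity, read by MTT assay, with a stated time of 72 h; a lower number here means a stronger inhibitor, a higher number a weaker inhibitor. For compound 1 the assay reports only a limit, > 100000 nM, and no number. Compound 2 gives 700 nM. Going by the values given here, the single measured step, an at least 140-fold lower number from compound 1 to compound 2 (2.15 log units; beyond the scatter), is known only as a lower bound because of the limit of > 100000 nM in this assay, at which 1 of the 2 values shown sits.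

Compound 3 differs from compound 1 in one place: 4-bromophenyl in place of methyl on an aromatic nitrogen. Among the compounds with values here, this is a change of the same kind as the one from compound 1 to compound 2, a substituted phenyl replacing methyl on the same aromatic nitrogen, so the expectation rests on that step alone. A large drop in the number is therefore expected, an at least 140-fold lower number from compound 1 to compound 3 (2.15 log units; beyond the scatter), in the same direction as the measured step. Because compound 2 gives 700 nM, compound 3 is estimated at 700 nM, with a range from 200 nM to 2500 nM.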

Compound 3, half-maximal inhibitory concentration: 3300 nM
Beside the measured number, compound 3's estimate is 4.7-fold (0.67 log units) below it, and the stated range ends below it.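

In this assay, 4-bromophenyl in place of methyl on the aromatic nitrogen gives an at least 30-fold lower number from compound 1 to compound 3 (1.48 log units; beyond the scatter), so the move away from the limit of compound 1 is not confined to the 4-methylphenyl of compound 2. What the phenyl ring carries also counts, since bromo in place of methyl on an aromatic carbon gives a 4.7-fold higher number from compound 2 to compound 3 (0.67 log units; beyond the scatter), a modest step beyond the scatter and smaller than the change that replacing methyl on the nitrogen brings. The change from methyl can still be stated only as a bound: the limit of > 100000 nM in this assay, at which 1 of the 3 values shown sits.

The compounds shown leave open whether a phenyl ring with no substituent, or one carrying an amine or a methoxy group, would give a number lower than that of compound 2. They also leave open whether a longer chain such as butyl, or a benzyl group, on the same aromatic nitrogen would bring any of the gain seen with the two substituted phenyl groups.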